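This account rests on a few compounds, and the source may have more. Where it says the series, first, only, none or still open, it means among the compounds named here.

Measured compounds:
- compound 1, `ClCc1cccc(Cn2cnc3c(Cl)ncnc32)c1`, 70800 nM in a functional assay on RXF 393 cells (Homo sapiens) for cytotoxicity, read by sulforhodamine B assay, with a stated time of 48 h; on this read-out higher numbers stand for lower toxicity in this test and lower numbers for higher toxicity in this test
- compound 2, `ClCc1ccc(Cn2cnc3nc(Cl)nc(Cl)c32)cc1`, no numerical result in this assay (recorded as "not determined" (no result reported))

Compound 2 therefore stands nowhere on the numbers shown: it carries no value in this assay, and the only measured figure in the series belongs to compound 1, which in this assay gives 70800 nM, a weak effect. Compound 3, `ClCc1ccc(Cn2cnc3ncnc(Cl)c32)cc1`, is the one still to be measured. Against compound 2 it differs by hydrogen in place of chloro on an aromatic carbon; in words, hydrogen in place of chloro on an aromatic carbon. Going by the values given here, no measured pair shows what such a change does, so the size of the step in this assay cannot be read off anything recorded, and the direction is open; the only anchor is the weak value of compound 1, which shares the remaining chloro-bearing core type with compound 3. With that anchor, compound 3 is expected to sit in the same weakly cytotoxic region, estimated at 60000 nM with a range of 15000 nM to 200000 nM, and a limit rather than a number is a real possibility.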

Compound 3, concentration lethal to 50% of the cells: 12000 nM
The estimate for compound 3 lay 5.0-fold (0.70 log units) above the measured number; measured number outside the range, below it.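

No new step can be read: in this assay compound 2 has no numerical result, so compound 3 at 12000 nM has no partner for comparison. Nothing recorded bears on the cause of this value. Going by these compounds, what hydrogen in place of chloro on an aromatic carbon does in this read-out remains open, in size and direction.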